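Cytotoxicity in a chloro-aryl amine series: amino variant

The source may hold more compounds than are shown below. What is called first, only, known or untested is meant among the compounds shown, and "the series" means these compounds.

Measured compounds:
compound 1 `CC(C)=CCOc1cc(Nc2nccs2)ccc1Cl` 26000 nM
compound 2 `CC(C)=CCOc1cc(Nc2ncccn2)ccc1Cl` 2500 nM
compound 3 `CC(C)=CCOc1cc(Nc2nccc(C(F)(F)F)n2)ccc1Cl` 2500 nM

In a functional assay on MT2 cells (Homo sapiens) for cytotoxicity, read by MTT assay (on this read-out higher numbers stand for lower toxicity in this test and lower numbers for higher toxicity in this test), compound 1 gives 26000 nM. The step of a 10-fold lower number from compound 1 to compound 2 (1.02 log units; beyond the scatter) is the only large move in the set. Compound 2 and compound 3 differ by no change at the digits printed from compound 2 to compound 3 (within the scatter), so compound 3 stands at 2500 nM, level with compound 2 and, together with it, at the lowest number of the three; compound 1 is the furthest from it.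

The next compound, compound 4 `CC(C)=CCOc1cc(Nc2nccc(N)n2)ccc1Cl`, is not yet measured. Its change from compound 3 is amino in place of trifluoromethyl on an aromatic carbon.

The step that bears most directly on this change is no change at the digits printed from compound 2 to compound 3 (within the scatter): exchanging hydrogen for trifluoromethyl at the same aromatic carbon left the read-out unchanged, which suggests that this position tolerates substitution without a marked shift. Within the data shown here, no step in the set involves an amino group, so its effect is unknown; the step of a 10-fold lower number from compound 1 to compound 2 (1.02 log units; beyond the scatter) concerns a different part of the structure and does not inform this change. On that basis no step beyond the scatter is expected, with a wider range allowed for the untested group. The expected step is a 1.2-fold higher number from compound 3 to compound 4 (0.08 log units; within the scatter). For compound 4 the estimate in this assay is 3000 nM, within a range from 1000 nM to 12000 nM.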

Compound 4, half-maximal cytotoxic concentration: 500 nM
For compound 4 the middle estimate is 6.0-fold (0.78 log units) above the measured one; the whole stated range lies above it.
By their numbers in this assay, from the lowest: compound 4; then compounds 2 and 3 (each within the scatter of the next); then compound 1.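

In this assay the aromatic carbon next to the ring nitrogen does not tolerate every substituent equally: amino gives a 5.0-fold lower number from compound 3 to compound 4 (0.70 log units; beyond the scatter) against trifluoromethyl and a 5.0-fold lower number from compound 2 to compound 4 (0.70 log units; beyond the scatter) against hydrogen, while trifluoromethyl and hydrogen had stood level. Of the three groups seen at this carbon, only amino, with its hydrogen-bond donor and acceptor where trifluoromethyl has neither, separates from the others, and the shift is towards higher toxicity in this test. With 4-aminopyrimidin-2-yl in place of 1,3-thiazol-2-yl, the series now spans a 52-fold lower number from compound 1 to compound 4 (1.72 log units; beyond the scatter) as its widest gap, and nothing available explains the amino effect.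

As far as these compounds go, whether this shift is specific to the free amino group remains open, as methylamino, dimethylamino, hydroxyl or methoxy at the same carbon would be needed to show how far it extends. Also open, from the compounds shown here alone, is whether amino would have a comparable effect on the thiazole of compound 1, or with another group in place of the chloro substituent on the shared core.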